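The source may hold more compounds than are shown below. What is called first, only, known or untested is meant among the compounds shown, and "the series" means these compounds.

Among the measured compounds shown here, in a functional assay on K562 cells (Homo sapiens) for cytotoxicity, read by trypan blue exclusion, with a stated time of 96 h (on this read-out lower numbers stand for stronger inhibition and higher numbers for weaker inhibition), compound 3 (`COc1cc(OC)c(/C=C/S(=O)(=O)Cc2ccc(OC)c(NC(F)(F)C(=O)O)c2)c(OC)c1`) gives 150 nM as the highest number so far, while compound 1 (`COC(=O)C(Nc1cc(CS(=O)(=O)/C=C/c2c(OC)cc(OC)cc2OC)ccc1OC)c1ccccc1`) gives 30 nM and compound 2 (`COc1cc(OC)c(/C=C/S(=O)(=O)Cc2ccc(OC)c(N[C@@H](C)C(=O)O)c2)c(OC)c1`) gives 15 nM on the same read-out. The next change is carboxy(phenyl)methyl in place of carboxy(difluoro)methyl on a nitrogen on an aromatic ring and leads to compound 4 (`COc1cc(OC)c(/C=C/S(=O)(=O)Cc2ccc(OC)c(NC(C(=O)O)c3ccccc3)c2)c(OC)c1`), with carboxy(phenyl)methyl in place of carboxy(difluoro)methyl on a nitrogen on an aromatic ring. For the measured compounds named here, two steps bear on it, namely a 5.0-fold higher number from compound 1 to compound 3 (0.70 log units; beyond the scatter) and also a 10-fold higher number from compound 2 to compound 3 (1.00 log units; beyond the scatter) with both beyond the scatter and both ending on the carboxy(difluoro)methyl group, whereas a 2.0-fold lower number from compound 1 to compound 2 (0.30 log units; within the scatter) stays within it. Going by the values given here, no measured step exchanges these two groups directly. A fall of similar size is expected, an estimated 5.0-fold lower number from compound 3 to compound 4 (0.70 log units; beyond the scatter) in this assay on this basis. For compound 4 the expected value is 30 nM with an estimated range from 10 nM to 90 nM as its ends.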

Compound 4, half-maximal inhibitory concentration: 15 nM
For compound 4 the middle estimate is 2.0-fold (0.30 log units) above the measured one, and the stated range covers the measured number.
By their numbers in this assay, from the lowest: compounds 2, 4 and 1 (each within the scatter of the next); then compound 3.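

In this assay the nitrogen on an aromatic ring accepts carboxy(phenyl)methyl well, with a 10-fold lower number from compound 3 to compound 4 (1.00 log units; beyond the scatter), so the carboxy(difluoro)methyl compound 3 stands apart from the other three. Between the two non-fluorinated acids, the change to carboxy(phenyl)methyl gives no change at the digits printed from compound 2 to compound 4 (within the scatter). Hydrogen in place of methyl on an oxygen next to a carbonyl group gives a 2.0-fold lower number from compound 1 to compound 4 (0.30 log units; within the scatter), so the methyl ester and its acid cannot be told apart here.

Open, on these data alone, is how an amide in place of the carboxylic acid, or a longer chain in place of the phenyl, would read at this nitrogen. No supporting data explain any of these steps.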